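Amino to hydroxy in the series, CCRF-CEM notes

A few compounds are considered here, and "the series" means these few. Any claim that something is new, unique, unknown or untested is made for them only; others in the source may bear on it.

Measured in a functional assay on CCRF-CEM cells (Homo sapiens), with a stated time of 3 days; a higher number here means a weaker inhibitor, a lower number a stronger inhibitor:
compound 1 `C=C1C=CCO[C@@H]1n1cc(C)c(O)nc1=O` gives 504000 nM
compound 2 `C=C1C=CCO[C@@H]1n1ccc(N)nc1=O` gives 1550000 nM

Compound 2 has the higher of the two numbers, and its gap to compound 1 lies beyond the scatter. Compound 3 `C=C1C=CCO[C@@H]1n1ccc(O)nc1=O` differs from compound 2 by one change, hydroxy in place of amino on an aromatic carbon. Among the measured compounds shown here, no measured pair isolates this change, so the expectation rests on compound 1, which also carries hydroxy and reads lower (504000 nM). A moderate fall in the number is expected, with the estimated step (a 2.4-fold lower number from compound 2 to compound 3 (0.38 log units; beyond the scatter)). For compound 3 the estimated value is 650000 nM (expected range 250000 nM to 1600000 nM).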

Compound 3, half-maximal inhibitory concentration: 450000 nM
Estimate against measurement, compound 3: 1.4-fold (0.16 log units) above, and the stated range covers the measured number.
By their numbers in this assay, from the lowest: compounds 3 and 1 (each within the scatter of the next); then compound 2.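

In this assay hydroxy in place of amino on an aromatic carbon now has a direct pair, free of the methyl carried by compound 1, and the step is beyond the scatter (a 3.4-fold lower number from compound 2 to compound 3 (0.54 log units; beyond the scatter)). Hydrogen in place of methyl on an aromatic carbon stays within the scatter (a 1.1-fold lower number from compound 1 to compound 3 (0.05 log units; within the scatter)), so the methyl makes no readable difference alongside hydroxy. No measurement on hand accounts for either step.

Open, as far as these compounds go, is how a methoxy or a carboxylic acid would read in place of the hydroxy. Also open, from the compounds shown here alone, is whether an ethyl or a longer chain in place of the methyl would stay within the scatter.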